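A few compounds are considered here, and "the series" means these few. Any claim that something is new, unique, unknown or untested is made for them only; others in the source may bear on it.

Three compounds have been measured in an ADME assay on liver for metabolic stability, with Liver microsome (Homo sapiens) as the target, read by LC-MS, using microsomes; a lower number here means slower removal, a higher number faster removal of the compound:

Compound 1 `CC1(C[C@@H](O)C(=O)N2N=CC[C@H]2C(=O)NCc2cc(Cl)ccc2-n2cnnn2)CC1`: < 12 mL.min-1.g-1 (a limit of the assay)
Compound 2 `COC(C)(C)[C@@H](O)C(=O)N1C[C@H]2C[C@H]2[C@H]1C(=O)NCc1cc(Cl)ccc1-n1cnnn1`: 23 mL.min-1.g-1
Compound 3 `O=C(NCc1cc(Cl)ccc1-n1cnnn1)[C@@H]1C[C@@H]2C[C@@H]2N1C(=O)[C@H](O)c1ccccc1F`: < 12 mL.min-1.g-1 (a limit of the assay)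

Among these three results, only compound 2 has a true number, at 23 mL.min-1.g-1. Compound 1 gives < 12 mL.min-1.g-1, which is a limit and not a number. Compound 3 gives < 12 mL.min-1.g-1, which is likewise a limit. The account now turns to compound 4 `O=C(NCc1cc(Cl)ccc1-n1cnnn1)[C@@H]1[C@@H]2C[C@@H]2CN1C(=O)[C@H](O)c1ccccc1`, which has not yet been measured in this assay. It differs from compound 2 by one change: phenyl in place of 1-methoxy-1-methylethyl on a saturated chain carbon bound to a carbonyl carbon and an oxygen on a saturated carbon.

Within the data shown here, no step between measured compounds is available to size this change, so the expectation rests on thin ground. For compound 4 a small downward move is expected because the limit of < 12 mL.min-1.g-1 in this assay, at which 2 of the 3 values shown sit, is the reading shared by compound 1 and compound 3. The expected step is a 1.6-fold lower number from compound 2 to compound 4 (0.22 log units; within the scatter), which would stay within the usual scatter. The result may also come back as a limit rather than a number. For compound 4 the estimated value is 14 mL.min-1.g-1, with an expected range of 7 mL.min-1.g-1 to 30 mL.min-1.g-1.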

Compound 4, intrinsic clearance in microsomes: < 15 mL.min-1.g-1
Compound 4 ended at the assay's limit; the forecaster's own chance of this, stated with the estimate: 45%; the middle value is on the limit's open side.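

Before compound 4, no two measured compounds differed in one place, so nothing sized a change at this position; replacing 1-methoxy-1-methylethyl with phenyl on a saturated chain carbon bound to a carbonyl carbon and an oxygen on a saturated carbon now gives a step in this assay: an at least 1.5-fold lower number from compound 2 to compound 4 (0.18 log units; that floor lies within the scatter). Among these compounds, with this change, compound 4 joins compound 1 and compound 3 in reading as a limit of the assay, which leaves compound 2 as the only compound with a true number. The full size of the step cannot be read because the reading of compound 4 is a limit and not a number: the limit of < 15 mL.min-1.g-1 in this assay, at which 1 of the 4 values shown sits.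

The compounds shown leave open how large the step really is, and whether the same change would read alike on the cores of compound 1 and compound 3. They also leave open how an amine or a carboxylic acid in place of phenyl on this saturated chain carbon would read in this assay.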